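A few compounds are considered here, and "the series" means these few. Any claim that something is new, unique, unknown or untested is made for them only; others in the source may bear on it.

Measured compounds:
compound 1, `CCCCCCCCNC(=O)[C@@H](NC(=O)/C=C/c1ccccc1)[C@@H](C)O`, 36000 nM
compound 2, `C/C=C/C=C/C(=O)N[C@H](C(=O)NCCCCCCCC)[C@@H](C)O`, 58200 nM
compound 3, `CCCCCCCCCCCCCCNC(=O)[C@@H](NC(=O)/C=C/c1ccccc1)[C@@H](C)O`, 64900 nM

All three were tested in a functional assay on A-431 cells (Homo sapiens) for cytotoxicity, read by MTT assay, with a stated time of 48 h; a higher number here means a weaker inhibitor, a lower number a stronger inhibitor. Compound 1 gives 36000 nM there, compound 2 gives 58200 nM, and compound 3 gives 64900 nM. The change from compound 1 to compound 2 is prop-1-en-1-yl in place of phenyl on a double-bonded chain carbon bound to a double-bonded chain carbon, and it made a step of a 1.6-fold higher number from compound 1 to compound 2 (0.21 log units; within the scatter). The change from compound 1 to compound 3 is hexyl in place of hydrogen on a saturated chain carbon, eight bonds along the chain from an amide-type nitrogen, with a step of a 1.8-fold higher number from compound 1 to compound 3 (0.26 log units; within the scatter). Compound 4, `C/C=C/C=C/C(=O)N[C@H](C(=O)NCCCCCCCCCCCCCC)[C@@H](C)O`, has not yet been measured in this assay. It differs from compound 3 by prop-1-en-1-yl in place of phenyl on a double-bonded chain carbon bound to a double-bonded chain carbon, which is the same change as that from compound 1 to compound 2, made on a core that differs from the core of compound 1 by hexyl in place of hydrogen on a saturated chain carbon, eight bonds along the chain from an amide-type nitrogen. Since that earlier step was a 1.6-fold higher number from compound 1 to compound 2 (0.21 log units; within the scatter), a step of similar size is expected from compound 3 to compound 4, namely a 1.5-fold higher number from compound 3 to compound 4 (0.17 log units; within the scatter). On this basis compound 4 is estimated at 95000 nM, expected to lie between 45000 nM and 200000 nM.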

Compound 4, half-maximal inhibitory concentration: > 200000 nM
Compound 4: a limit, no number (the forecaster's own chance of this, stated with the estimate: 25%); middle value at least 2.1-fold (0.32 log units) from the limit.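

In this assay compound 4 gives > 200000 nM, which is a limit of the assay and not a number. On the core of compound 3, prop-1-en-1-yl in place of phenyl gives an at least 3.0-fold higher number from compound 3 to compound 4 (0.48 log units; beyond the scatter), so the change weakens this longer-chain compound, but the limit does not fix the size of the step or show that the change behaves differently on the two cores: the same change on two cores in this assay, a 1.6-fold higher number (0.21 log units; within the scatter) from compound 1 to compound 2 and an at least 3.0-fold higher number (0.48 log units; beyond the scatter) from compound 3 to compound 4; the limit leaves it open whether they differ. The longer chain, read on the prop-1-en-1-yl side, gives an at least 3.4-fold higher number from compound 2 to compound 4 (0.53 log units; beyond the scatter), and the same caution applies to carrying that change across: the same change on two cores in this assay, a 1.8-fold higher number (0.26 log units; within the scatter) from compound 1 to compound 3 and an at least 3.4-fold higher number (0.53 log units; beyond the scatter) from compound 2 to compound 4; the limit leaves it open whether they differ.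

On these data alone, the true position of compound 4 remains unknown, so any dependence of one change on the other can be neither confirmed nor excluded: the limit of > 200000 nM in this assay, at which 1 of the 4 values shown sits. The compounds shown also leave open how a decyl chain on the amide nitrogen would fit into this picture, and whether a phenyl group bearing an amine would behave like the phenyl of compound 3.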